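The source may hold more compounds than are shown below. What is called first, only, known or untested is meant among the compounds shown, and "the series" means these compounds.

Working notes on the series. Compound 1 `COc1ccc(NC(=O)NC2CC(C)(C)Oc3ccc(F)cc32)cc1` in a functional assay (aorta) with Rattus norvegicus as the target (a lower number here means that less compound is needed, a higher number that more compound is needed for the effect), gives 15500 nM. Compound 2 `Cc1ccc(NC(=O)NC2CC(C)(C)Oc3ccc(F)cc32)cc1` gives in this assay only a limit, > 30000 nM, and no number; the bar is described by the limit of > 30000 nM in this assay, at which 1 of the 2 values shown sits. The only measured step is an at least 1.9-fold higher number from compound 1 to compound 2 (0.28 log units; that floor lies within the scatter), a move whose floor does not leave the scatter, so compound 2 stands no better placed than compound 1 on the numbers shown, and how much further it lies is unknown.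

Compound 3 `CC1(C)CC(NC(=O)Nc2cccc(Cl)c2)c2cc(F)ccc2O1` differs from compound 2 by 3-chlorophenyl in place of 4-methylphenyl on an amide-type nitrogen. Within the data shown here, no measured step touches a 3-chlorophenyl group, and the one step available, an at least 1.9-fold higher number from compound 1 to compound 2 (0.28 log units; that floor lies within the scatter), concerns a different group on the same ring and is itself only a floor. Its size gives no ground to expect a move beyond the scatter in this assay, in either direction; the estimated step is a number no higher from compound 2 to compound 3 (the limit leaves the size open). For compound 3 in this assay the expected value is 30000 nM, with a range from 9000 nM to 90000 nM, and a real chance that only a limit is reported.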

Compound 3, half-maximal effective concentration: > 300000 nM
Compound 3 was reported as a limit (the forecaster's own chance of this, stated with the estimate: 50%); at least 10-fold (1.00 log units) between middle value and limit.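

Compound 3 is reported only as a limit, not a number: the limit of > 300000 nM in this assay, at which 1 of the 3 values shown sits.

Among these compounds, with 3-chlorophenyl in place of 4-methoxyphenyl on the amide-type nitrogen, the series shows an at least 19-fold higher number from compound 1 to compound 3 (1.28 log units; beyond the scatter), the first step in this assay whose floor leaves the scatter, so the group on this nitrogen can move the read-out by more than the scatter. Among the compounds shown here, the step between the two compounds reported as limits cannot be read, so 3-chlorophenyl and 4-methylphenyl cannot be ranked against each other, and compound 1 remains the only compound here with a number.

It stays open whether the higher number from compound 1 to compound 3 follows the chlorine, its place on the phenyl ring or the loss of the methoxy group, as the compounds shown include no 4-chlorophenyl or 3-methoxyphenyl group on this nitrogen. Also open, as far as these compounds go, are how far the true values of compound 2 and compound 3 lie beyond their limits and whether an amine or a carboxylic acid on the same phenyl ring would give a number in this assay.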